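The source may hold more compounds than are shown below. What is called first, only, known or untested is meant among the compounds shown, and "the series" means these compounds.

Working notes on the series. The shared core is carried by compound 1 `O=C1O[C@H]([C@@H](O)Cn2cc(CNS(=O)(=O)c3ccc(F)cc3)nn2)C(OCc2ccccc2)=C1OCc1ccccc1`, compound 2 `O=C1O[C@H]([C@@H](O)Cn2cc(C3CC3)nn2)C(OCc2ccccc2)=C1OCc1ccccc1` and compound 3 `CCCCCc1ccc(-c2cn(C[C@H](O)[C@H]3OC(=O)C(OCc4ccccc4)=C3OCc3ccccc3)nn2)cc1`. In a functional assay on HeLa cells (Homo sapiens) for antiproliferative activity, read by MTT assay, with a stated time of 72 h (a higher number here means a weaker inhibitor, a lower number a stronger inhibitor), compound 1 gives 25000 nM. In this assay compound 2 gives 26500 nM, and the step of a 1.1-fold higher number from compound 1 to compound 2 (0.03 log units; within the scatter) lies within the scatter. In this assay compound 3 gives 8390 nM, the lowest of the three numbers, with both a 3.0-fold lower number from compound 1 to compound 3 (0.47 log units; beyond the scatter) and a 3.2-fold lower number from compound 2 to compound 3 (0.50 log units; beyond the scatter) beyond the scatter. Compound 4 `CCCCc1cn(C[C@H](O)[C@H]2OC(=O)C(OCc3ccccc3)=C2OCc2ccccc2)nn1` has not yet been measured. It differs from compound 3 in one place: butyl in place of 4-pentylphenyl on an aromatic carbon. Butyl, like cyclopropyl, brings no ring. The step of a 3.2-fold lower number from compound 2 to compound 3 (0.50 log units; beyond the scatter) therefore bears most closely on the change, and the step of a 3.0-fold lower number from compound 1 to compound 3 (0.47 log units; beyond the scatter) points the same way. Taking away the 4-pentylphenyl in favour of butyl is expected to give back most of that modest gain, so a higher number in this assay is expected, of about a 2.6-fold higher number from compound 3 to compound 4 (0.42 log units; beyond the scatter). The estimate for compound 4 in this assay is 22000 nM, expected to fall between 8000 nM and 50000 nM. For the measured compounds named here, only one step in the set gives a read on this change, so the range is kept wide and the measured value will decide.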

Compound 4, half-maximal inhibitory concentration: 18100 nM
The estimate for compound 4 lay 1.2-fold (0.08 log units) above the measured number; the measured number falls inside the stated range.
By their numbers in this assay, from the lowest: compound 3; then compounds 4, 1 and 2 (each within the scatter of the next).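

In this assay, the step of a 2.2-fold higher number from compound 3 to compound 4 (0.33 log units; beyond the scatter) shows that a plain butyl chain on this aromatic carbon does not keep what the 4-pentylphenyl gives, so the earlier contrast with cyclopropyl and the sulfonamide-bearing arm was not special to those two groups. Butyl instead falls in with them: a 1.5-fold lower number from compound 2 to compound 4 (0.17 log units; within the scatter) and a 1.4-fold lower number from compound 1 to compound 4 (0.14 log units; within the scatter) both lie within the scatter, so these three groups cannot be told apart at this position, and among the four compounds only compound 3 stands clear of the rest, though by a modest margin. No measurement is at hand that explains this difference.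

Still open, going by these compounds, is whether the ring or the pentyl chain on it carries the modest gain; an unsubstituted phenyl and a longer straight chain such as octyl on the same carbon would separate the two. Also open, on these data alone, is how this position would respond to a charged group such as an amine or a carboxylic acid at the end of the chain.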